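This account rests on a few compounds, and the source may have more. Where it says the series, first, only, none or still open, it means among the compounds named here.

Compound 3 `CC(=O)c1ccc(NC(=O)CSc2nc3c(c(=O)n2-c2ccccc2)SCC3)cc1` is one of three analogues sharing one core and differing only in the substituent on the anilide ring. In an assay on L cells for inhibition of Protein-serine O-palmitoleoyltransferase porcupine (Mus musculus), read by reporter gene assay, with a stated time of 24 h (on this read-out higher numbers stand for an effect only at larger amounts of compound and lower numbers for an effect already at smaller amounts), compound 3 gives a limit of the assay, > 1000 nM, and no number. Compound 1 `CCOc1ccc(NC(=O)CSc2nc3c(c(=O)n2-c2ccccc2)SCC3)cc1` gives 1000 nM in this assay. Compound 2 `CN(C)c1ccc(NC(=O)CSc2nc3c(c(=O)n2-c2ccccc2)SCC3)cc1` likewise reaches only a limit in this assay, > 1000 nM. The steps of a number no lower from compound 1 to compound 3 (the limit leaves the size open) and a step that the two limits leave unreadable from compound 2 to compound 3 are therefore of unreadable size, since the limit of > 1000 nM in this assay, at which 2 of the 3 values shown sit, hides how far compound 3 actually lies. Compound 4 `CCOC(=O)c1ccc(NC(=O)CSc2nc3c(c(=O)n2-c2ccccc2)SCC3)cc1` differs from compound 3 by ethoxy in place of methyl on a carbonyl carbon; no measured pair tests this change, so nothing shown predicts a step beyond the scatter in this assay. Compound 3 standing at the limit, compound 4 is expected to remain weak, around 1800 nM (range 500 nM to 6000 nM), an estimated step that the limit leaves unreadable from compound 3 to compound 4.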

Compound 4, half-maximal effective concentration: 300 nM
Beside the measured number, compound 4's estimate is 6.0-fold (0.78 log units) above it; measured number outside the range, below it.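

Ethoxy in place of methyl on a carbonyl carbon gives an at least 3.3-fold lower number from compound 3 to compound 4 (0.52 log units; beyond the scatter) in this assay, the first step in this series with a size beyond the scatter. Ethoxycarbonyl likewise gives an at least 3.3-fold lower number from compound 2 to compound 4 (0.52 log units; beyond the scatter) and a 3.3-fold lower number from compound 1 to compound 4 (0.52 log units; beyond the scatter), so the substituent at this place on the anilide ring can shift the read-out towards effect at smaller amounts. Two of these steps remain open-ended because of a limit: the limit of > 1000 nM in this assay, at which 2 of the 4 values shown sit.

Going by these compounds, it remains open whether the gain needs the ethoxy part of the group. A carboxylic acid, a primary amide or a longer chain in place of ethoxy would test this.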